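The compounds below may be only part of what the source reports. "The series", "measured", "known", "first", "only" and "open" are said of these compounds alone.

In a functional assay, tested at 50 ug/mL (a lower number here means a weaker effect, a higher number a stronger effect of the compound at the concentration tested), the starting point is compound 1 `O=S(=O)(CC1=NCCO1)c1n[nH]cc1-c1ccc(Cl)cc1`, for which the read-out is given only as "not active" (no number reported), without a number. Its companion compound 2 `O=S(=O)(CC1=NCCO1)c1n[nH]cc1-c1ccccc1` gives 53.3% in this assay, so within this small set compound 2 shows a measurable effect where compound 1 shows none. The compound that has not yet been measured is compound 3 `O=S(=O)(CC1=NCCS1)c1n[nH]cc1-c1ccc(Cl)cc1`. It differs from compound 1 in one place: a group of 5 heavy atoms (3 carbon, 1 nitrogen, 1 sulfur; one five-membered non-aromatic ring with 2 hetero atoms) in place of a group of 5 heavy atoms (3 carbon, 1 nitrogen, 1 oxygen; one five-membered non-aromatic ring with 2 hetero atoms), on a saturated chain carbon bound to a sulfonyl sulfur. For the measured compounds named here, since compound 1 carries no number, no step between measured compounds can be computed for this change, and the size of its effect in this assay has to be guessed from what compound 1 itself shows. The expectation is that the change from the oxygen-containing ring to the sulfur-containing ring leaves compound 3 on the weak side, with a fair chance that it too is reported only as not active. For compound 3 the activity in this assay is estimated at 15%, with a likely range from 0% to 40%.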

Compound 3, a percentage reported as activity, at one concentration (the size of the read-out at that concentration, not a potency): "not active" (no number reported)
No number was reported for compound 3; the estimate stays without a comparison.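

In this assay compound 1 and compound 3 are both reported as "not active" without a number, so no step can be read for the change of the ring oxygen to sulfur. Nothing on record bears on this result. The compounds shown leave open whether this ring change has any effect on a core that gives a measurable read-out.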